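Extending the Acid Chain of Compound 1

A few compounds are considered here, and "the series" means these few. Any claim that something is new, unique, unknown or untested is made for them only; others in the source may bear on it.

Measured compounds:
compound 1, `O=C(O)c1ccc(NCc2cccc(Oc3ccccc3)c2)cc1` — < 10000 nM
compound 2, `Cc1nc(-c2ccc(C(F)(F)F)cc2)sc1CNc1ccc(C(=O)O)cc1` — < 10000 nM
compound 3, `Cc1nc(-c2ccc(C(F)(F)F)cc2)sc1CNc1ccc(CC(=O)O)cc1` — < 10000 nM

In a functional assay on CHO cells for agonist activity at Free fatty acid receptor 1 (Homo sapiens) (a lower number here means that less compound is needed, a higher number that more compound is needed for the effect), compound 1 gives < 10000 nM, which is a limit of the assay and not a number. Compound 2 gives < 10000 nM, also a limit. Compound 3 gives < 10000 nM, again a limit. So compound 1 stands only at a limit, as do the two others; all three values sit at the same limit (the limit of < 10000 nM in this assay, at which 3 of the 3 values shown sit), and no compound can be ranked against another.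

The step to compound 4, `O=C(O)/C=C/c1ccc(NCc2cccc(Oc3ccccc3)c2)cc1`, is 2-carboxyethenyl in place of carboxy on an aromatic carbon. The closest measured comparison is the step from compound 2 to compound 3, a step that the two limits leave unreadable from compound 2 to compound 3, which also lengthens the acid chain from the ring but whose size is hidden by the two limits. For the measured compounds named here, there is thus no measured step that tells how large or in which direction the change from compound 1 to compound 4 in this assay should be.

On this basis the estimate for compound 4 is 3000 nM, within a range from 500 nM to 10000 nM. This expected result corresponds to a step that the limit leaves unreadable from compound 1 to compound 4, which means a value placed centrally under the limit that compound 1 only touches, with wide uncertainty on both sides.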

Compound 4, half-maximal effective concentration: 145 nM
Beside the measured number, compound 4's estimate is 21-fold (1.32 log units) above it; measured number outside the range, below it.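

The step from compound 1 to compound 4 cannot be read, because the value of compound 1 is a limit of the assay and not a number: the limit of < 10000 nM in this assay, at which 3 of the 4 values shown sit. The compounds shown leave open how large the effect of 2-carboxyethenyl in place of carboxy is in this assay, and in which direction it goes.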